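The source may report more compounds than this note shows. Statements on the series, on what has been measured and on what is new or still open speak of the compounds shown alone.

Compound 1 `Clc1cccc(Nc2n[nH]c3ccccc23)c1`: 84 nM
Compound 2 `Clc1cccc(Nc2n[nH]c3ccc(Cl)cc23)c1`: 5 nM
Compound 3 `Clc1cccc(Nc2n[nH]c3ccc(Br)cc23)c1`: 21 nM

Of the compounds shown here, three have so far been measured in an assay for inhibition of acyl-CoA (8-3)-desaturase (Homo sapiens); on this read-out lower numbers stand for stronger inhibition and higher numbers for weaker inhibition. They share one core and differ only in a single group on one of its aromatic rings. Compound 3 gives 21 nM in this assay, the second highest of the three numbers. The nearest of the other numbers is reached by a 4.0-fold lower number from compound 1 to compound 3 (0.60 log units; beyond the scatter), and the furthest by a 4.2-fold higher number from compound 2 to compound 3 (0.62 log units; beyond the scatter).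

Compound 4 `FC(F)(F)c1ccc2[nH]nc(Nc3cccc(Cl)c3)c2c1` has not yet been measured. It differs from compound 3 in one place: trifluoromethyl in place of bromo on an aromatic carbon. Among the measured compounds shown here, no measured step swaps bromo for trifluoromethyl, so the expectation rests on what the two halogens at that position showed. Filling the position gave a 17-fold lower number from compound 1 to compound 2 (1.23 log units; beyond the scatter) and a 4.0-fold lower number from compound 1 to compound 3 (0.60 log units; beyond the scatter), and exchanging one halogen for the other gave a 4.2-fold higher number from compound 2 to compound 3 (0.62 log units; beyond the scatter). Changes at this position therefore move the number, yet there is no trifluoromethyl example to fix the direction. The number for compound 4 is expected to stay near the middle of the measured range, estimated as 20 nM with a range from 6 nM to 70 nM. That estimate means an expected 1.1-fold lower number from compound 3 to compound 4 (0.02 log units; within the scatter), within the usual scatter.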

Compound 4, half-maximal inhibitory concentration: 254 nM
Compound 4: middle estimate off by 13-fold (1.10 log units), on the low side; the measured number lies above the stated range.
By their numbers in this assay, from the lowest: compound 2; then compound 3; then compound 1; then compound 4.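

In this assay, trifluoromethyl at this position gives a 3.0-fold higher number from compound 1 to compound 4 (0.48 log units; beyond the scatter) and so ends up on the weaker side of the unsubstituted compound, whereas chloro and bromo both lowered the number from that same starting point. Set against the halogens, the loss is larger still, with a 12-fold higher number from compound 3 to compound 4 (1.08 log units; beyond the scatter) against bromo and a 51-fold higher number from compound 2 to compound 4 (1.71 log units; beyond the scatter) against chloro. Compound 4 is therefore the weakest of the four, with every step to it beyond the scatter, and the position turns out to be sensitive to which group sits there: filling it does not by itself bring a lower number, and the direction of the change depends on the group.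

No measurement shown here accounts for the different behaviour of trifluoromethyl and the two halogens. The compounds shown also leave open whether a fluoro, methyl, methoxy, nitrile or amine group at this position would follow chloro and bromo towards lower numbers or follow trifluoromethyl towards higher ones.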